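Salicylanilide series: removing one bromo group from compound 3

This account rests on a few compounds, and the source may have more. Where it says the series, first, only, none or still open, it means among the compounds named here.

Measured so far in an assay on isolated protein for inhibition of thiosulfate sulfurtransferase (Homo sapiens), with a stated time of 60 min, in the absence of a further agent; a higher number here means a weaker inhibitor, a lower number a stronger inhibitor:
Compound 1, `O=C(Nc1cccc(Cl)c1)c1cc(Br)cc(Br)c1O`, returns only the assay limit > 100000 nM.
Compound 2, `O=C(Nc1ccccc1)c1cccc(Br)c1`, returns only the assay limit > 100000 nM.
Compound 3, `O=C(Nc1ccccc1)c1cc(Br)cc(Br)c1O`, returns only the assay limit > 100000 nM.

Compound 3 therefore stands at the limit, and no ordering within the series can be read, since every value shown sits at the limit of > 100000 nM in this assay, at which 3 of the 3 values shown sit. Among the compounds with values here, the only single-point step with measured ends, a step that the two limits leave unreadable from compound 1 to compound 3, joins two limits and its size is not readable. Compound 4, `O=C(Nc1ccccc1)c1cccc(Br)c1O`, differs from compound 3 by hydrogen in place of bromo on an aromatic carbon. Within the data shown here, no measured step concerns this change; the step between compound 1 and compound 3 touches the other ring, and compound 2, which carries no hydroxy group and one bromo group, gives nothing beyond its limit either. With all three values at the limit, no gain is indicated; the step from compound 3 to compound 4 is expected to be a number no higher from compound 3 to compound 4 (the limit leaves the size open), nothing beyond the scatter. Compound 4 is expected near 100000 nM, between 30000 nM and 300000 nM, most probably reported again only as a limit.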

Compound 4, half-maximal inhibitory concentration: > 100000 nM
Compound 4 was reported as a limit; the forecaster's own chance of this, stated with the estimate: 85%; the middle value sits exactly at the limit.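

Compound 2, compound 3 and compound 4 yield no readable step, since both ends of each step are limits: the limit of > 100000 nM in this assay, at which 4 of the 4 values shown sit.

The compounds shown leave open how strongly any of them inhibits, and whether any change on the shared core gives a measurable value.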